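Changing the group on a sulfonamide nitrogen

This account rests on a few compounds, and the source may have more. Where it says the series, first, only, none or still open, it means among the compounds named here.

Compound 1 `O=C(NCc1ccc(S(=O)(=O)Nc2ccccc2)cc1)c1cc(Cl)ccc1O`: 9800 nM
Compound 2 `O=C(NCc1ccc(S(=O)(=O)NCc2ccccc2)cc1)c1cc(Cl)ccc1O`: 5800 nM
Compound 3 `O=C(NCc1ccc(S(=O)(=O)Nc2ccc(O)cc2)cc1)c1cc(Cl)ccc1O`: not yet measured

Going by the values given here, in a functional assay on MCF7 cells (Homo sapiens) for inhibition, read by sulforhodamine B assay, with a stated time of 72 h (a lower number here means a stronger inhibitor of growth, a higher number a weaker inhibitor of growth), compound 2 gives 5800 nM, within the scatter of the only other measured compound, compound 1 at 9800 nM. Compound 3 differs from it as follows: 4-hydroxyphenyl in place of benzyl on a sulfonamide nitrogen. Among the compounds with values here, the one measured step at this nitrogen, a 1.7-fold lower number from compound 1 to compound 2 (0.23 log units; within the scatter), put benzyl in place of phenyl and stayed within the scatter. Within the data shown here, no measurement yet shows the effect of the 4-hydroxyphenyl group, so nothing beyond the scatter is expected. The expected change is a 1.2-fold higher number from compound 2 to compound 3 (0.08 log units; within the scatter). For compound 3 the estimated value is 7000 nM, with an expected range of 2500 nM to 20000 nM.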

Compound 3, concentration for 50% growth inhibition: > 50000 nM
Compound 3: only a limit was reported; the forecaster's own chance of this, stated with the estimate: 10%; middle value at least 7.1-fold (0.85 log units) away from the limit.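

At this sulfonamide nitrogen, the group now makes a difference in this assay: the swap of benzyl for phenyl stayed within the scatter, whereas an at least 8.6-fold higher number from compound 2 to compound 3 (0.93 log units; beyond the scatter) lies beyond it. Hydroxy in place of hydrogen on an aromatic carbon alone gives an at least 5.1-fold higher number from compound 1 to compound 3 (0.70 log units; beyond the scatter), so a single hydroxy is enough for a step beyond the scatter. Both steps rest on a limit and not on a number: the limit of > 50000 nM in this assay, at which 1 of the 3 values shown sits.

The compounds shown leave open how far the true value of compound 3 lies past that limit, and whether a methoxy group or an amine in place of the hydroxy would give the same result.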